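Hydroxy for carboxymethyl: expected cytotoxicity of compound 3

The source may hold more compounds than are shown below. What is called first, only, known or untested is meant among the compounds shown, and "the series" means these compounds.

compound 1 `O=c1c(Br)cc2ccccc2n1Cc1nc2ccccc2n1CCCCF` (26200 nM)
compound 2 `CC(C)CCn1c(CN2C(=O)C(CC(=O)O)c3ccccc32)nc2ccccc21` (16500 nM)

Both values come from an ADME assay on HEp-2 cells (Homo sapiens) for cytotoxicity; on this read-out higher numbers stand for lower toxicity in this test and lower numbers for higher toxicity in this test. Compound 2 (16500 nM) lies within the scatter of compound 1 (26200 nM), so the two cannot be told apart on the numbers available.

Compound 3 `CC(C)CCn1c(CN2C(=O)C(O)c3ccccc32)nc2ccccc21` differs from compound 2 by hydroxy in place of carboxymethyl on a saturated ring carbon with hydroxy in place of carboxymethyl on a saturated ring carbon. Among the compounds with values here, no measured pair differs in one place, so this change has no direct precedent. Compound 1 at 26200 nM and compound 2 at 16500 nM differ widely in structure yet stay within the scatter, so no step beyond the scatter is expected in either direction. The estimated change is a 1.1-fold higher number from compound 2 to compound 3 (0.04 log units; within the scatter) in this assay and is expected to stay within the scatter. Expected for compound 3 is 18000 nM with 7000 nM to 50000 nM as the estimated range.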

Compound 3, half-maximal cytotoxic concentration: 3310 nM
For compound 3 the middle estimate is 5.4-fold (0.74 log units) above the measured one, and the stated range ends above it.
By their numbers in this assay, from the lowest: compound 3; then compounds 2 and 1 (each within the scatter of the next).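

In this assay, within the data shown here, the saturated ring carbon of the five-membered non-aromatic ring gives the first one-place comparison, and the change is not neutral: hydroxy in place of carboxymethyl produces a 5.0-fold lower number from compound 2 to compound 3 (0.70 log units; beyond the scatter), a modest step beyond the scatter toward higher toxicity in this test. The two groups carry the same counts of hydrogen-bond donors and acceptors and no net charge, and they differ in heavy atoms and in the double bond outside aromatic rings. No supporting measurement bears on what lies behind the step.

Among these compounds, only this one pair speaks to this carbon, so it stays open whether an amine, a methoxy group or a longer chain ending in a carboxylic acid would move the number the same way. On these data alone, it also stays open whether the step carries over when the other chain on the shared core is changed.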